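Trimming the tail of compound 3

The source may report more compounds than this note shows. Statements on the series, on what has been measured and on what is new or still open speak of the compounds shown alone.

Measured so far:
- compound 1 `C#Cc1cccc(Nc2ncnc3ccc(NC(=O)Nc4ccc(CN5CCN(C)CC5)cc4)cc23)c1` gives 2810 nM in a functional assay on A-431 cells (Homo sapiens) for antiproliferative activity, read by MTT assay, with a stated time of 72 h; on this read-out higher numbers stand for weaker inhibition and lower numbers for stronger inhibition
- compound 2 `COc1ccc(Nc2ncnc3ccc(NC(=O)Nc4ccc(CN5CCN(C)CC5)cc4)cc23)cc1Cl` gives 2010 nM in this assay
- compound 3 `O=C(Nc1ccc(CN2CCCC2)cc1)Nc1ccc2ncnc(Nc3cccc(C(F)(F)F)c3)c2c1` gives 1360 nM in this assay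

Compound 3 has the lowest of the three numbers, but its gap to compound 2 lies within the scatter, while its gap to compound 1 lies beyond it. Compound 4 `O=C(Nc1ccccc1)Nc1ccc2ncnc(Nc3cccc(C(F)(F)F)c3)c2c1` differs from compound 3 in one place: hydrogen in place of (pyrrolidin-1-yl)methyl on an aromatic carbon. Going by the values given here, the only measured step, a 1.4-fold lower number from compound 1 to compound 2 (0.15 log units; within the scatter), concerns the other nitrogen-linked ring and says nothing about this tail, so no measured step bears on the change. With no guide, the expected step is a 1.8-fold higher number from compound 3 to compound 4 (0.26 log units; within the scatter), carrying a wide range. Compound 4 is therefore estimated at 2500 nM, between 700 nM and 9000 nM.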

Compound 4, half-maximal inhibitory concentration: > 10000 nM
Compound 4: a limit, no number; the forecaster's own chance of this, stated with the estimate: 5%; at least 4.0-fold (0.60 log units) between middle value and limit.
By their numbers in this assay, from the lowest: compounds 3, 2 and 1 (each within the scatter of the next, the first and the last beyond it). At a limit, above all of these: compound 4.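

Compound 4 sits at > 10000 nM, which is a limit of the assay and not a number. Putting hydrogen in place of (pyrrolidin-1-yl)methyl gives an at least 7.3-fold higher number from compound 3 to compound 4 (0.86 log units; beyond the scatter), the first step shown that touches this tail and the first that lies beyond the scatter. This pair shows that, in this assay, the activity of compound 3 depends heavily on what sits at this aromatic carbon.

As far as these compounds go, what remains open is which part of the group counts, the nitrogen or the ring. A dimethylamino-methyl group, a morpholin-4-ylmethyl group or a carboxylic acid at this position could help tell these apart.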